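Extending the Oxime Ether Chain of Compound 3

A few compounds are considered here, and "the series" means these few. Any claim that something is new, unique, unknown or untested is made for them only; others in the source may bear on it.

Of the compounds shown here, three sharing one core have been measured in a physicochemical assay for lipophilicity, measured as octanol-water partition; on this read-out lower numbers stand for lower lipophilicity and higher numbers for higher lipophilicity. Compound 1 `CCO/N=C/Nc1cc(Cl)c(F)c(Cl)c1` gives 4. Compound 2 `CCCCc1c(Cl)cc(N/C=N/OCC)cc1Cl` gives 5.6. Compound 3 `C#CCc1c(Cl)cc(N/C=N/OC)cc1Cl` gives 3.3, the lowest of the three numbers; compound 1 is the nearest to it and compound 2 the furthest, both separated from it beyond the scatter.

Compound 4 `C#CCc1c(Cl)cc(N/C=N/OC/C=C/Cl)cc1Cl` has not yet been measured. It differs from compound 3 in one place: 2-chloroethenyl in place of hydrogen on a saturated chain carbon bound to an oxygen. Seen one bond further out, methoxy becomes (3-chloroprop-2-en-1-yl)oxy.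

Going by the values given here, only one measured step exists, a number 1.60 log units higher from compound 1 to compound 2 (beyond the scatter), and it sits on an aromatic carbon rather than on the chain bound to the oxygen, so it bears on compound 4 only as a sign that adding carbon-based groups raises this read-out strongly. The addition here is shorter than butyl, so a clearly smaller rise is expected. Compound 4 is therefore expected to give 4.5, within 3.9 to 5.1. The expected step is a number 1.20 log units higher from compound 3 to compound 4 (beyond the scatter).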

Compound 4, partition coefficient: 3.9
The estimate for compound 4 lay 0.60 log units above the measured number, within the range that was stated.
By their numbers in this assay, from the lowest: compound 3; then compounds 4 and 1 (each within the scatter of the next); then compound 2.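

Going by these compounds alone, this is the first measured change on the saturated chain carbon bound to an oxygen, and it shows that this place is not silent in this assay: 2-chloroethenyl in place of hydrogen gives a number 0.60 log units higher from compound 3 to compound 4 (beyond the scatter) and this is a modest step. Within the data shown here, the only earlier step, a number 1.60 log units higher from compound 1 to compound 2 (beyond the scatter) and large, involves a different group on an aromatic carbon, so the two sizes cannot be set against each other as a measure of position alone. Nothing available here explains the size of the new step.

On these data alone, whether the chlorine of the new group contributes remains open, since a plain ethenyl group on the same carbon would be needed to separate it from the added carbons. As far as these compounds go, how an amine, a carboxylic acid or a longer saturated chain such as hexyl would behave at this place is also open.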